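Chloro for Fluoro on a Second Cinnamoyl Sulfonamide Core

The compounds below may be only part of what the source reports. "The series", "measured", "known", "first", "only" and "open" are said of these compounds alone.

Three compounds have been measured in a functional assay on B16-F10 cells (Mus musculus) for antiproliferative activity, read by ELISA and MTT assay, with a stated time of 48 h; a higher number here means a weaker inhibitor, a lower number a stronger inhibitor:
compound 1, `O=C(/C=C/c1ccc(Br)cc1)NS(=O)(=O)c1ccc(F)cc1`, gives 1.2 ug/mL;
compound 2, `O=C(/C=C/c1ccc(Br)cc1)NS(=O)(=O)c1ccc(Cl)cc1`, gives 5.2 ug/mL;
compound 3, `CN(C)c1ccc(/C=C/C(=O)NS(=O)(=O)c2ccc(F)cc2)cc1`, gives 2.3 ug/mL.

The change from compound 1 to compound 2 is chloro in place of fluoro on an aromatic carbon and it made a step of a 4.3-fold higher number from compound 1 to compound 2 (0.64 log units; beyond the scatter) in this assay. The core of compound 3 differs from that of compound 1 by dimethylamino in place of bromo on an aromatic carbon, a step of a 1.9-fold higher number from compound 1 to compound 3 (0.28 log units; within the scatter).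

Compound 4, `CN(C)c1ccc(/C=C/C(=O)NS(=O)(=O)c2ccc(Cl)cc2)cc1`, carries the same change on the core of compound 3: chloro in place of fluoro on an aromatic carbon. Because the earlier instance gave a 4.3-fold higher number from compound 1 to compound 2 (0.64 log units; beyond the scatter), a step of similar size, a 3.3-fold higher number from compound 3 to compound 4 (0.51 log units; beyond the scatter), is expected for compound 4 in this assay, though a single precedent is a thin basis. Compound 4 is therefore estimated at 7.5 ug/mL, most likely between 3 ug/mL and 20 ug/mL.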

Compound 4, half-maximal inhibitory concentration: 2.8 ug/mL
The estimate for compound 4 lay 2.7-fold (0.43 log units) above the measured number; the whole stated range lies above it.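

In this assay, chloro in place of fluoro on the core of compound 3 gave a 1.2-fold higher number from compound 3 to compound 4 (0.09 log units; within the scatter), so the change did not carry over with the size it had on the core of compound 1: the same change on two cores in this assay, a 4.3-fold higher number (0.64 log units; beyond the scatter) from compound 1 to compound 2 and a 1.2-fold higher number (0.09 log units; within the scatter) from compound 3 to compound 4, 3.6-fold (0.55 log units) apart, beyond the scatter of two such steps

The other change, dimethylamino in place of bromo, gave a 1.9-fold lower number from compound 2 to compound 4 (0.27 log units; within the scatter), and it too differs from its earlier instance: the same change on two cores in this assay, a 1.9-fold higher number (0.28 log units; within the scatter) from compound 1 to compound 3 and a 1.9-fold lower number (0.27 log units; within the scatter) from compound 2 to compound 4, 3.6-fold (0.55 log units) apart, beyond the scatter of two such steps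

Across these four compounds, then, the effect of each change depends on the group present at the other end of the molecule, but two cores show neither why this happens nor how the change would behave on a third core.

From the compounds shown here alone, whether a core carrying a methoxy group in place of bromo would follow compound 1 or compound 3 remains open. So does the effect of a methyl group in place of fluoro on either core.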